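A few compounds are considered here, and "the series" means these few. Any claim that something is new, unique, unknown or untested is made for them only; others in the source may bear on it.

In an ADME assay on L1210/0 cells (Mus musculus) for cytotoxicity, with a stated time of 48 h (a lower number here means a stronger inhibitor, a higher number a weaker inhibitor), the measured compounds are:

Compound 1 `O=c1[nH]c(=O)n([C@H]2C[C@H](O)[C@@H](CO)O2)cc1C#CCO`: > 200000 nM
Compound 2 `CCCC#Cc1cn([C@H]2C[C@H](O)[C@@H](CO)O2)c(=O)[nH]c1=O`: > 200000 nM
Compound 3 `O=c1[nH]c(=O)n([C@H]2C[C@H](O)[C@@H](CO)O2)cc1/C=C/Cl`: > 200000 nM

Each of these values is a limit of the assay and not a number. Compound 3 therefore has no exact place on the scale, and the same is true of the other two compounds: the limit of > 200000 nM in this assay, at which 3 of the 3 values shown sit.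

Compound 4 `C#COc1cn([C@H]2C[C@H](O)[C@@H](CO)O2)c(=O)[nH]c1=O` carries ethynyloxy in place of 2-chloroethenyl on an aromatic carbon. Two measured steps change the group at this same place: a step that the two limits leave unreadable from compound 1 to compound 3 and a step that the two limits leave unreadable from compound 2 to compound 3. Neither has a size that can be read, so they give no direction for the new step. With three different groups all ending at the limit, no step beyond the scatter is expected in this assay, although this is weak evidence. A further reading that gives only a limit is the likeliest outcome.

The expected change is a number no higher from compound 3 to compound 4 (the limit leaves the size open).

For compound 4 the estimated value is 200000 nM, with an expected range from 60000 nM to 400000 nM.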

Compound 4, half-maximal inhibitory concentration: > 200000 nM
Compound 4: a limit, no number; the forecaster's own chance of this, stated with the estimate: 75%; the middle value lies on the limit itself.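

Among these compounds, no step between compound 4 and compound 1, compound 2 or compound 3 can be read in this assay, since all four values are limits and not numbers: the limit of > 200000 nM in this assay, at which 4 of the 4 values shown sit. The compounds shown leave open how far apart they truly stand, and whether any group at this place would give a readable number.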